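Working notes: from compound 3 to compound 4

The source may hold more compounds than are shown below. What is called first, only, known or untested is meant among the compounds shown, and "the series" means these compounds.

In a functional assay on DU-145 cells (Homo sapiens) for inhibition, read by trypan blue exclusion, with a stated time of 96 h (on this read-out higher numbers stand for weaker inhibition of growth and lower numbers for stronger inhibition of growth), compound 3 `O=C(/C(=C\c1ccc(OC(F)(F)F)cc1)Sc1ccc(Br)cc1)c1ccc(Br)cc1` gives 10000 nM, the middle of three numbers. Compound 2 `O=C(/C(=C\c1ccc(Oc2ccccc2)cc1)Sc1ccc(Br)cc1)c1ccc(Br)cc1` stands higher at 50000 nM, and compound 1 `O=C(/C(=C\c1ccc(Br)c(O)c1)Sc1ccc(Br)cc1)c1ccc(Br)cc1` stands lowest at 1000 nM. Compound 4 `O=C(/C(=C\c1ccc(Cl)cc1)Sc1ccc(Br)cc1)c1ccc(Br)cc1` carries chloro in place of trifluoromethoxy on an aromatic carbon, para to a large group: chloro in place of trifluoromethoxy on an aromatic carbon. Within the data shown here, the only measured step bearing on this place is a 5.0-fold lower number from compound 2 to compound 3 (0.70 log units; beyond the scatter), modest but beyond the scatter, and it points to lower numbers. Among the measured compounds shown here, no measured compound with chloro at this place exists, so that single step gives only weak guidance. The expected step, slightly downward and within the scatter, is a 1.7-fold lower number from compound 3 to compound 4 (0.22 log units; within the scatter). The estimate for compound 4 is 6000 nM, with an expected range from 1500 nM to 20000 nM.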

Compound 4, concentration for 50% growth inhibition: 1000 nM
For compound 4 the middle estimate is 6.0-fold (0.78 log units) above the measured one; measured number outside the range, below it.
By their numbers in this assay, from the lowest: compounds 1 and 4 (each within the scatter of the next); then compound 3; then compound 2.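

In this assay at this aromatic carbon, chloro in place of trifluoromethoxy gives a 10-fold lower number from compound 3 to compound 4 (1.00 log units; beyond the scatter) and chloro in place of phenoxy gives a 50-fold lower number from compound 2 to compound 4 (1.70 log units; beyond the scatter) at the same place. Chloro therefore carries the lowest number of the three groups seen here, a single heavy atom against two groups joined through oxygen. The change of the whole ring gives no change at the digits printed from compound 1 to compound 4 (within the scatter) so 4-chlorophenyl and 4-bromo-3-hydroxyphenyl cannot be told apart in this read-out.

Nothing at hand gives a reason for these steps. Open, on these data alone, is how bromo, an amine or a carboxylic acid at this aromatic carbon would compare with chloro.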